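A few compounds are considered here, and "the series" means these few. Any claim that something is new, unique, unknown or untested is made for them only; others in the source may bear on it.

Compound 1 `CCCCCCCCCCCCNC(=O)[C@@H](NC(=O)c1cc2ccccc2o1)[C@@H](C)O` is the starting point of this small set. In a functional assay on SiHa cells (Homo sapiens) for cytotoxicity, read by MTT assay, with a stated time of 48 h (a lower number here means a stronger inhibitor, a higher number a weaker inhibitor), compound 1 gives 12900 nM. Compound 2 `CCCCCCCCCCCCNC(=O)[C@@H](NC(=O)c1nccc2ccccc12)[C@@H](C)O` differs from it in a single place: isoquinolin-1-yl in place of 1-benzofuran-2-yl on a carbonyl carbon. In this assay compound 2 gives 56600 nM, so the step is a 4.4-fold higher number from compound 1 to compound 2 (0.64 log units; beyond the scatter). Compound 3 `CCCCCCCCCCCCCCCCCCNC(=O)[C@@H](NC(=O)c1cc2ccccc2o1)[C@@H](C)O` keeps the core of compound 1 but carries a longer chain. For compound 3 in this assay the result is only a limit of the assay, > 200000 nM. The step is therefore an at least 15-fold higher number from compound 1 to compound 3 (1.19 log units; beyond the scatter), and it runs into (the limit of > 200000 nM in this assay, at which 1 of the 3 values shown sits).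

Compound 4 `CCCCCCCCCCCCCCCCCCNC(=O)[C@@H](NC(=O)c1nccc2ccccc12)[C@@H](C)O` has not yet been measured in this assay. It differs from compound 3 by isoquinolin-1-yl in place of 1-benzofuran-2-yl on a carbonyl carbon, the same change that separates compound 2 from compound 1, and in both pairs the change sits in the same place, on a carbonyl carbon whose other neighbours are an amide-type nitrogen. The two cores on which the change is made differ by hexyl in place of hydrogen on a saturated chain carbon, ten or more bonds along the chain from an amide-type nitrogen.

Because the earlier occurrence of this change gave a 4.4-fold higher number from compound 1 to compound 2 (0.64 log units; beyond the scatter), compound 4 is expected to be weaker again than compound 3, and the expected step is a step that the limit leaves unreadable from compound 3 to compound 4. Compound 4 is thus estimated in this assay at 800000 nM. The estimate for compound 4 is expected to fall between 200000 nM and 4000000 nM, and it is expected that the assay will once more return only a limit.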

Compound 4, half-maximal inhibitory concentration: 51200 nM
Estimate against measurement, compound 4: 16-fold (1.19 log units) above; measured number below the stated range.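

In this assay, the exchange of 1-benzofuran-2-yl for isoquinolin-1-yl on the carbonyl carbon did not carry over from one core to the other: on the core with the longer chain its direction reversed, giving an at least 3.9-fold lower number from compound 3 to compound 4 (0.59 log units; beyond the scatter), and the two steps differ clearly: the same change on two cores in this assay, a 4.4-fold higher number (0.64 log units; beyond the scatter) from compound 1 to compound 2 and an at least 3.9-fold lower number (0.59 log units; beyond the scatter) from compound 3 to compound 4, at least 17-fold (1.23 log units) apart, beyond the scatter of two such steps. The longer chain likewise behaved differently on the two groups, since with isoquinolin-1-yl in place it gave a 1.1-fold lower number from compound 2 to compound 4 (0.04 log units; within the scatter), in contrast to its step with 1-1-benzofuran-2-yl removed from consideration here: the same change on two cores in this assay, an at least 15-fold higher number (1.19 log units; beyond the scatter) from compound 1 to compound 3 and a 1.1-fold lower number (0.04 log units; within the scatter) from compound 2 to compound 4, at least 17-fold (1.23 log units) apart, beyond the scatter of two such steps. Compound 3 stands at a limit of the assay and not at a number, so the reversal has a bound rather than a size, and these two pairs show that the effect of the change depends on the core here without showing why: the limit of > 200000 nM in this assay, at which 1 of the 4 values shown sits.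

What the compounds shown leave open is how the same exchange behaves on a chain of any other length, such as a shorter chain or one of intermediate length. Also open, as far as these compounds go, is whether the reversal would hold with a different group on the carbonyl carbon, or with an amine or a carboxylic acid at the end of the chain.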